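Extending the amine end of compound 1

The source may report more compounds than this note shows. Statements on the series, on what has been measured and on what is new or still open speak of the compounds shown alone.

Compound 1 `CN(C)CCCOc1ccccc1/C=C/c1ccccc1` holds the higher of the two numbers gathered so far in a functional assay on the whole organism with Mus musculus as the target, in the maximal electroshock model, at a dose of 50 mg/kg by the oral route; a lower number here means less inhibition, a higher number more inhibition at the dose given (going by the name of the read-out): compound 1 gives 14.2%. Compound 2 `CN(C)CCCCOc1ccccc1/C=C/c1ccc(Cl)cc1` gives 0% in this assay, a reading that lies below that of compound 1 by more than the scatter. For the measured compounds named here, compound 2 differs from compound 1 in more than one place, so no single step between the two measured compounds can be drawn from them. Compound 3 `CN(C)CCN(C)CCCCOc1ccccc1/C=C/c1ccccc1` is still to be measured; it differs from compound 1 by ((2-(dimethylamino)ethyl)(methyl)amino)methyl in place of dimethylamino on a saturated chain carbon, three bonds along the chain from an oxygen on an aromatic ring. Going by the values given here, with no measured step to lean on and both readings low, the change from compound 1 to compound 3 is not expected to move the reading beyond the scatter in either direction. Compound 3 is expected to give 15% in this assay, within a range of 0% to 40%. The expected step is a number 0.8 percentage points higher from compound 1 to compound 3 (within the scatter).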

Compound 3, a percentage reported as inhibition, in the whole organism at one dose (the size of the read-out at that dose, not a potency): 0%
For compound 3 the middle estimate is 15 percentage points above the measured one; low and high end bracket the measured number.
By their numbers in this assay, from the lowest: compounds 2 and 3 (each within the scatter of the next); then compound 1.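

Working from this assay, the change at this position gives a number 14.2 percentage points lower from compound 1 to compound 3 (beyond the scatter), the first step in the series that can be read at a single place. Here, ((2-(dimethylamino)ethyl)(methyl)amino)methyl, which carries more heavy atoms and one more nitrogen than dimethylamino, does not keep the modest reading of compound 1 at this dose. No available measurement bears on the reason for this drop.

This single step does not separate the added chain length from the added nitrogen, and a longer chain ending in a simple dimethylamino group would be needed to separate them. Going by these compounds, whether a different terminal amine on the shorter chain of compound 1, such as diethylamino, would keep or raise the reading also remains open.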